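The compounds below may be only part of what the source reports. "The series", "measured", "known", "first", "only" and "open" are said of these compounds alone.

Of the compounds shown here, two from this series have been tested so far, and they share a common core with a methylamide-bearing pyridine ether linked through an amide to a substituted six-membered aromatic ring. Compound 1 `CNC(=O)c1cc(Oc2ccc(NC(=O)c3nccc(-c4ccccc4)n3)cc2)ccn1` carries a plain phenyl on that ring; in a functional assay on MCF7 cells (Homo sapiens) for cytotoxicity, read by MTT assay, with a stated time of 72 h (on this read-out lower numbers stand for stronger inhibition and higher numbers for weaker inhibition), compound 1 gives 39100 nM, which is the highest number, that is the weakest cytotoxic effect, of the two values available. Compound 2 `CNC(=O)c1cc(Oc2ccc(NC(=O)c3cc(-c4ccc(C)cc4)ncn3)cc2F)ccn1`, which differs from it in several places at once, gives 19200 nM in this assay, a lower number that lies beyond the usual scatter.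

The next compound, compound 3 `CNC(=O)c1cc(Oc2ccc(NC(=O)c3nccc(-c4ccc([N+](=O)[O-])cc4)n3)cc2)ccn1`, changes compound 1 in one place only: nitro in place of hydrogen on an aromatic carbon. Among the compounds with values here, no measured pair in this set shows what such a change does in this assay, so the direction of the step cannot be read from the data at hand. The expected step is a 1.3-fold lower number from compound 1 to compound 3 (0.12 log units; within the scatter). Compound 3 is therefore estimated at 30000 nM, within a range from 10000 nM to 90000 nM in this assay.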

Compound 3, half-maximal inhibitory concentration: > 100000 nM
Compound 3: a limit, no number; the forecaster's own chance of this, stated with the estimate: 20%; middle value at least 3.3-fold (0.52 log units) away from the limit.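

In this assay compound 3 gives > 100000 nM, which is a limit of the assay and not a number: the limit of > 100000 nM in this assay, at which 1 of the 3 values shown sits.

Nitro in place of hydrogen on this aromatic carbon, para to a large group, gives an at least 2.5-fold higher number from compound 1 to compound 3 (0.40 log units; beyond the scatter). Within the data shown here, this is the first change that can be read in one place alone, and on this read-out a higher number stands for weaker inhibition, so phenyl to 4-nitrophenyl moves the compound in the unfavourable direction, and by more than the usual scatter of repeated measurements. The earlier compounds shown here could not show this, as compound 1 and compound 2 differ in several places at once and say nothing about this carbon taken by itself.

On these data alone, what remains open is whether this loss belongs to nitro in particular or would follow from other groups on the same carbon, such as an amine, a methoxy group or a carboxylic acid. Only such neighbours of compound 1 could show whether any group at this position lowers the number, and the present data give no reason for the step.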